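The source may hold more compounds than are shown below. What is called first, only, known or untested is meant among the compounds shown, and "the series" means these compounds.

Compound 1 `COc1cc2cc(Oc3ccc(NC(=O)Nc4ccc(C)cc4)cc3)c(C)nc2cc1OC` gives 66.9% in a functional assay on HOP-62 cells (Homo sapiens) for inhibition, read by sulforhodamine B assay, with a stated time of 48 h, tested at 10 uM; on this read-out higher numbers stand for a weaker effect at the one concentration tested and lower numbers for a stronger effect.
Compound 2 `COc1cc2cc(Oc3ccc(NC(=O)Nc4ccc(Cl)c(C(F)(F)F)c4)cc3)c(C)nc2cc1OC` gives -51% in this assay.

Compound 2 stands lowest of the two numbers in this assay; its nearest is compound 1, and a number 117.9 percentage points lower from compound 1 to compound 2 (beyond the scatter) separates them. Compound 3 `COc1cc2cc(Oc3ccc(NC(=O)Nc4ccc(Cl)c(Cl)c4)cc3)c(C)nc2cc1OC` differs from compound 2 by chloro in place of trifluoromethyl on an aromatic carbon. Among the compounds with values here, no measured step matches this change; the only step known, a number 117.9 percentage points lower from compound 1 to compound 2 (beyond the scatter), concerns a larger swap and bears on it only loosely. A step smaller than that one is therefore expected, about a number 21 percentage points higher from compound 2 to compound 3 (beyond the scatter), toward a weaker effect. Compound 3 is estimated at -30%, within -70% to 20%.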

Compound 3, a percentage reported as activity, at one concentration (the size of the read-out at that concentration, not a potency): 55.2%
Beside the measured number, compound 3's estimate is 85.2 percentage points below it, and the stated range ends below it.
By their numbers in this assay, from the lowest: compound 2; then compound 3; then compound 1.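

Read in this assay, the change from trifluoromethyl to chloro on this aromatic carbon, with the 4-chloro group kept, gives a number 106.2 percentage points higher from compound 2 to compound 3 (beyond the scatter) and so undoes nearly all of the strong effect. The 3,4-dichlorophenyl group, by contrast, stays close to 4-methylphenyl, with a number 11.7 percentage points lower from compound 1 to compound 3 (beyond the scatter) as the step, so among these three compounds the strong effect appears only with trifluoromethyl. Nothing available explains why this one group matters so much.

Open, on these data alone, is whether bromo, nitrile or methoxy at this place would behave like trifluoromethyl or like chloro, and whether trifluoromethyl needs the 4-chloro group to give this effect.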